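Adding a methyl to the benzyl ring of compound 3

A few compounds are considered here, and "the series" means these few. Any claim that something is new, unique, unknown or untested is made for them only; others in the source may bear on it.

Measured so far:
compound 1 `Cc1nn2cnnc2cc1Cc1ccccc1` gives 9.5 mg/kg
compound 2 `Cc1nn2c(C)nnc2cc1Cc1ccccc1` gives 26 mg/kg
compound 3 `Cc1nn2c(N)nnc2cc1Cc1ccccc1` gives 22 mg/kg

All three numbers come from a functional assay on the whole organism with Mus musculus as the target, in the maximal electroshock model; on this read-out lower numbers stand for an effect already at smaller amounts and higher numbers for an effect only at larger amounts of compound. Compound 3 sits second highest of the three: its nearest neighbour is compound 2, within the scatter, and its furthest is compound 1, where the step of a 2.3-fold higher number from compound 1 to compound 3 (0.36 log units; beyond the scatter) lies beyond the scatter. The other measured steps are a 2.7-fold higher number from compound 1 to compound 2 (0.44 log units; beyond the scatter) and a 1.2-fold lower number from compound 2 to compound 3 (0.07 log units; within the scatter).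

Compound 4 `Cc1ccc(Cc2cc3nnc(N)n3nc2C)cc1` differs from compound 3 by methyl in place of hydrogen on an aromatic carbon, placed on an aromatic carbon of a six-membered aromatic ring of carbon only, para to a large group. For the measured compounds named here, none of the measured steps touches this ring; all three concern the shared core, so no step bears directly on the change. The measured steps were at most modest, so the step of a 1.1-fold higher number from compound 3 to compound 4 (0.06 log units; within the scatter) is expected to stay within the scatter, with no clear direction. Compound 4 is therefore estimated at 25 mg/kg, within a range from 11 mg/kg to 55 mg/kg.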

Compound 4, dose for half-maximal effect: 22.5 mg/kg
Estimate against measurement, compound 4: 1.1-fold (0.05 log units) above, and the stated range covers the measured number.
By their numbers in this assay, from the lowest: compound 1; then compounds 3, 4 and 2 (each within the scatter of the next).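

In this assay, methyl in place of hydrogen on the six-membered aromatic ring of carbon only, para to a large group, gives a 1.0-fold higher number from compound 3 to compound 4 (0.01 log units; within the scatter). For the compounds shown here, this is the first look at that ring, and here the added methyl brings no shift beyond the scatter, so the dose needed for the effect stays where it was. The same exchange of hydrogen for methyl therefore does not count equally at every place in these compounds: the same change on two cores in this assay, a 2.7-fold higher number (0.44 log units; beyond the scatter) from compound 1 to compound 2 and a 1.0-fold higher number (0.01 log units; within the scatter) from compound 3 to compound 4, 2.7-fold (0.43 log units) apart, beyond the scatter of two such steps

Still open, on these data alone, is whether a different group at this place, such as a chlorine atom, a methoxy group or a carboxylic acid, would also leave the number in place. Also open, as far as these compounds go, is how the same methyl on this ring would behave on the core of compound 1, which carries hydrogen where compound 3 carries amino.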